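Adding a Chloro to the Second Phenyl Ring

The source may hold more compounds than are shown below. What is called first, only, known or untested is meant among the compounds shown, and "the series" means these compounds.

Measured compounds and their values in a functional assay on MDA-MB-231 cells (Homo sapiens) for antiproliferative activity, with a stated time of 72 h; a lower number here means a stronger inhibitor, a higher number a weaker inhibitor:
compound 1 `Cn1c(N2N=C(c3ccccc3)CC2c2ccc(Cl)cc2)nc(-c2ccccc2)c(C#N)c1=O`: 28000 nM
compound 2 `COc1ccc(C2CC(c3ccccc3)=NN2c2nc(-c3ccccc3)c(C#N)c(=O)n2C)cc1`: 12800 nM
compound 3 `Cn1c(N2N=C(c3ccccc3)CC2c2ccc(F)cc2)nc(-c2ccccc2)c(C#N)c1=O`: 11800 nM

Compound 2 stands second highest of the three numbers in this assay. Compound 3 sits close to it, a 1.1-fold lower number from compound 2 to compound 3 (0.04 log units; within the scatter), so the two cannot be told apart, while compound 1 lies clearly above, a 2.2-fold lower number from compound 1 to compound 2 (0.34 log units; beyond the scatter).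

Compound 4 `COc1ccc(C2CC(c3ccc(Cl)cc3)=NN2c2nc(-c3ccccc3)c(C#N)c(=O)n2C)cc1` differs from compound 2 by chloro in place of hydrogen on an aromatic carbon. For the measured compounds named here, the measured steps all swap one group for another on the ring that carries the methoxy in compound 2; none adds a chloro to a phenyl that was bare, so no step speaks directly to this change. The only hint is that a chloro on the other ring gave the highest number, a 2.2-fold lower number from compound 1 to compound 2 (0.34 log units; beyond the scatter) and a 2.4-fold lower number from compound 1 to compound 3 (0.38 log units; beyond the scatter), but that concerns a different ring. In this assay compound 4 is therefore expected to show no step beyond the scatter, a 1.1-fold lower number from compound 2 to compound 4 (0.03 log units; within the scatter). The estimate for compound 4 is 12000 nM, within a range of 4000 nM to 36000 nM.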

Compound 4, half-maximal inhibitory concentration: 11100 nM
Compound 4: middle estimate off by 1.1-fold (0.03 log units), on the high side; measured number inside the range.
By their numbers in this assay, from the lowest: compounds 4, 3 and 2 (each within the scatter of the next); then compound 1.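

In this assay, replacing the phenyl of compound 2 with a 4-chlorophenyl leaves the number within the scatter (a 1.2-fold lower number from compound 2 to compound 4 (0.06 log units; within the scatter)), so this position takes a chloro in place of hydrogen without a change that can be told apart from repeat measurements. For the compounds shown here, the earlier steps all exchanged one group for another on the ring that carries the methoxy in compound 2, so this is the first reading of a change on the other ring. Nothing measured here bears on why this chloro leaves the number where it is.

A single chloro is the only group shown at this position, so it remains open whether an amine, a carboxylic acid or a longer chain would move the number beyond the scatter. On these data alone, whether a chloro on this ring would behave the same way with a different group on the methoxy-bearing ring also remains open.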